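Smaller amine ring on the thiocarbonyl: an expectation for compound 4

This account rests on a few compounds, and the source may have more. Where it says the series, first, only, none or still open, it means among the compounds named here.

Measured so far:
compound 1 `O=c1c(CSC(=S)N2CCCCC2)coc2cc(Cl)ccc12`: 280 nM
compound 2 `COc1ccc2occ(CSC(=S)N3CCCC3)c(=O)c2c1`: 3100 nM
compound 3 `O=c1c(Cl)c(CSC(=S)N2CCCCC2)oc2ccccc12`: 940 nM

In a functional assay on HEp-2 cells (Homo sapiens) for antiproliferative activity, read by MTT assay, with a stated time of 72 h (on this read-out higher numbers stand for weaker inhibition and lower numbers for stronger inhibition), compound 1 gives 280 nM and holds the lowest of the three numbers. The nearest number is that of compound 3 at 940 nM, a gap beyond the scatter; the furthest is that of compound 2 at 3100 nM, also beyond the scatter. So compound 1 is the strongest inhibitor among the three measured compounds.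

Compound 4 `O=c1c(CSC(=S)N2CCCC2)coc2cc(Cl)ccc12` is not yet measured. It differs from compound 1 in one place: pyrrolidin-1-yl in place of piperidin-1-yl on a thiocarbonyl carbon. Going by the values given here, no pair of measured compounds isolates this change. Compound 2 carries the same pyrrolidin-1-yl and gives 3100 nM, but its core differs from that of compound 1 as well, so its value says little on its own about the amine ring.

A small step is expected, more likely towards a higher number than a lower one, and possibly within the scatter. For compound 4 the estimate in this assay is 500 nM, with a range from 150 nM to 1600 nM, which corresponds to an expected step of a 1.8-fold higher number from compound 1 to compound 4 (0.25 log units; within the scatter).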

Compound 4, half-maximal inhibitory concentration: 2100 nM
Estimate against measurement, compound 4: 4.2-fold (0.62 log units) below, outside the stated range (above it).
By their numbers in this assay, from the lowest: compound 1; then compound 3; then compounds 4 and 2 (each within the scatter of the next).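

On the core of compound 1, the amine ring on the thiocarbonyl carbon proves to be a position that responds to a small change: in this assay, pyrrolidin-1-yl in place of piperidin-1-yl gives a 7.5-fold higher number from compound 1 to compound 4 (0.88 log units; beyond the scatter), a step well clear of the usual variation between repeats. Going by these compounds alone, this is the only pair so far that isolates the amine ring, and on this core it favours the six-membered non-aromatic ring over the five-membered one, so piperidin-1-yl is the better of the two groups compared here. Nothing at hand gives a measured reason for the difference between these two rings, and the step stands as an observation only.

From the compounds shown here alone, whether the same preference holds on other cores stays open, since this single pair rests on the core of compound 1 alone. Also open, going by these compounds, is how the position responds to amines beyond these two rings, such as a seven-membered azepan-1-yl, a morpholin-4-yl with its ring oxygen, a piperazin-1-yl or an open-chain diethylamino group, which would show whether piperidin-1-yl is a peak or part of a wider trend.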